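Triazole series: cyclopropyl for pyridyl on the shared core

The source may report more compounds than this note shows. Statements on the series, on what has been measured and on what is new or still open speak of the compounds shown alone.

Two compounds carry numbers in a functional assay on the whole organism (strain CF-1) with Mus musculus as the target; on this read-out higher numbers stand for an effect only at larger amounts of compound and lower numbers for an effect already at smaller amounts. Compound 1 `NCC(=O)Nc1ccc(Cl)cc1C(=O)c1ccccc1` gives 5.6 mg/kg in this assay, while compound 2 `CN(C)Cc1nnc(-c2ccncc2)n1-c1ccc(Cl)cc1C(=O)c1ccccc1Cl` gives 20 mg/kg, the higher of the two numbers; the two compounds differ in many places, so their values are only read side by side. Compound 3 `CN(C)Cc1nnc(C2CC2)n1-c1ccc(Cl)cc1C(=O)c1ccccc1Cl` carries cyclopropyl in place of pyridin-4-yl on an aromatic carbon. Within the data shown here, no single-point step with a measured result exists for this change, so the expected step from compound 2 to compound 3 in this assay is set near zero, none beyond the scatter, giving no change at the digits printed from compound 2 to compound 3 (within the scatter). Compound 3 is therefore estimated at 20 mg/kg, within 8 mg/kg to 50 mg/kg.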

Compound 3, dose for half-maximal effect: 1.1 mg/kg
Compound 3: middle estimate off by 18-fold (1.26 log units), on the high side; measured number below the stated range.
By their numbers in this assay, from the lowest: compound 3; then compound 1; then compound 2.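

In this assay, cyclopropyl in place of pyridin-4-yl gives an 18-fold lower number from compound 2 to compound 3 (1.26 log units; beyond the scatter), so the group on this aromatic carbon, between two ring nitrogen atoms, has a large bearing on the dose read-out. On this shared core, the lower number goes with the three-membered carbon ring rather than the six-membered aromatic ring with its ring nitrogen. No measurement shown accounts for the step. Still open, from the compounds shown here alone, is whether the step follows ring size, the ring nitrogen or aromaticity; phenyl, cyclobutyl or methyl on this carbon would separate these. Also open, going by these compounds, is whether it persists with a different group in place of (dimethylamino)methyl.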